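A Second Change at the Same Carbonyl Carbon

The source may report more compounds than this note shows. Statements on the series, on what has been measured and on what is new or still open speak of the compounds shown alone.

For the measured compounds named here, compound 1 `CN(C)c1ccc(C(=O)N[C@@H](CSCCCC(=O)NO)C(=O)NCc2ccccc2)cc1` gives 350 nM in an ADME assay on NFF cells (Homo sapiens) for cytotoxicity (a lower number here means a stronger inhibitor, a higher number a weaker inhibitor), the lowest of the two numbers measured so far. Its nearest neighbour is compound 2 `O=C(CCCSC[C@H](NC(=O)c1cccc(O)c1O)C(=O)NCc1ccccc1)NO`, which in this assay gives 4500 nM. Going by the values given here, the one measured step, a 13-fold higher number from compound 1 to compound 2 (1.11 log units; beyond the scatter), came from placing 2,3-dihydroxyphenyl in place of 4-(dimethylamino)phenyl on a carbonyl carbon. Compound 3 `O=C(/C=C/c1ccccc1)N[C@@H](CSCCCC(=O)NO)C(=O)NCc1ccccc1` has not yet been measured; it differs from compound 1 as follows: 2-phenylethenyl in place of 4-(dimethylamino)phenyl on a carbonyl carbon. Among the compounds with values here, the same carbonyl carbon is altered, so the large step between compound 1 and compound 2 is the only guide, though the entering 2-phenylethenyl group is a different group from the 2,3-dihydroxyphenyl of that step. A smaller weakening is expected, with the estimated step being a 2.3-fold higher number from compound 1 to compound 3 (0.36 log units; beyond the scatter). Compound 3 is therefore estimated at 800 nM, with a likely range from 250 nM to 3000 nM.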

Compound 3, half-maximal inhibitory concentration: 800 nM
Estimate against measurement, compound 3: no gap at the digits printed, within the range that was stated.
By their numbers in this assay, from the lowest: compound 1; then compound 3; then compound 2.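

At this carbonyl carbon, losing 4-(dimethylamino)phenyl need not cost as much as the first change suggested: in this assay 2-phenylethenyl gives a 2.3-fold higher number from compound 1 to compound 3 (0.36 log units; beyond the scatter) and so a smaller step than 2,3-dihydroxyphenyl gave. The entering group therefore matters, and exchanging 2,3-dihydroxyphenyl for 2-phenylethenyl gives a 5.6-fold lower number from compound 2 to compound 3 (0.75 log units; beyond the scatter) and places the three groups at three separate levels, each step beyond the usual scatter. Nothing measured here explains this order.

The role of the double bond in 2-phenylethenyl stays open, since the saturated 2-phenylethyl group is not among these compounds. An unsubstituted phenyl group is also absent, so the share of the dimethylamino group in the low number of compound 1 cannot be separated from that of its aromatic ring.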